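The source may hold more compounds than are shown below. What is called first, only, known or untested is meant among the compounds shown, and "the series" means these compounds.

Within the data shown here, in a physicochemical assay for solubility, read by chemiluminescence, measured as kinetic solubility (on this read-out higher numbers stand for higher solubility and lower numbers for lower solubility), compound 1 `COc1nn(C2COC2)c2ncnc(NS(=O)(=O)c3cccc(Cl)c3Cl)c12` gives 142000 nM, the only value so far that is not a limit. Compound 2 `COc1nn(C)c2nc(C)nc(NS(=O)(=O)c3cccc(Cl)c3Cl)c12` reports only a limit, >= 557000 nM. Compound 3 `COc1nn(C)c2nc(N)nc(NS(=O)(=O)c3cccc(Cl)c3Cl)c12` also stands only at a limit, >= 649000 nM. Among the measured compounds shown here, the one measured step, a step that the two limits leave unreadable from compound 2 to compound 3, offers no size to carry forward. Compound 4 `COc1nn(C)c2nc(NC3COC3)nc(NS(=O)(=O)c3cccc(Cl)c3Cl)c12` differs from compound 3 by a single change: oxetan-3-yl in place of hydrogen on a nitrogen on an aromatic ring. For the measured compounds named here, no measured step covers this change directly. Going by the values given here, compound 1 also carries an oxetan-3-yl group, and its 142000 nM is the only guide, so a downward move is expected. The estimated step is an at least 2.1-fold lower number from compound 3 to compound 4 (0.33 log units; beyond the scatter). Compound 4 is estimated at 300000 nM, within an expected range of 110000 nM to 700000 nM.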

Compound 4, solubility: >= 712000 nM
Compound 4: a limit, no number; the forecaster's own chance of this, stated with the estimate: 35%; middle value at least 2.3-fold (0.37 log units) from the limit.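

Among these compounds, compound 2, compound 3 and compound 4 each stand only at a limit, so no step among them can be read. The compounds shown leave open whether oxetan-3-yl in place of hydrogen changes solubility at all.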